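This account rests on a few compounds, and the source may have more. Where it says the series, first, only, none or still open, it means among the compounds named here.

Of the compounds shown here, three built on a shared core have been tested in a functional assay on A549 cells (Homo sapiens) for antiproliferative activity, read by MTT assay; on this read-out lower numbers stand for stronger inhibition and higher numbers for weaker inhibition. Compound 1 `COc1ccc(-c2ccnc(Nc3ccc([N+](=O)[O-])cc3)n2)cc1` gives 2730 nM, compound 2 `Cc1cccc(Nc2nccc(-c3ccc(Br)cc3)n2)c1` gives 63200 nM, and compound 3 `COc1ccc(-c2ccnc(Nc3ccc(Cl)cc3Cl)n2)cc1` gives 7330 nM. Compound 3 therefore holds the second highest of the three numbers, and its gaps to the other two lie beyond the usual scatter of repeated measurements.

The next compound is compound 4 `Clc1ccc(Nc2nccc(-c3ccc(Br)cc3)n2)c(Cl)c1`, which keeps everything in compound 3 except for one group: bromo replaces methoxy on an aromatic carbon, para to a large group (bromo in place of methoxy on an aromatic carbon). For the measured compounds named here, no measured pair of compounds shows this change on its own, so any forecast rests on thin evidence. Going by the values given here, the only clue is that compound 2, which also carries the bromo, gives 63200 nM, the highest number so far. Compound 2 also differs from compound 3 elsewhere, so this clue cannot be pinned on the bromo alone. A moderate move towards a higher number, meaning weaker inhibition, therefore seems more likely than no change. The expected change is a 2.5-fold higher number from compound 3 to compound 4 (0.39 log units; beyond the scatter). For compound 4 the estimated value is 18000 nM, with an expected range of 6000 nM to 60000 nM.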

Compound 4, half-maximal inhibitory concentration: 3780 nM
Beside the measured number, compound 4's estimate is 4.8-fold (0.68 log units) above it; the whole stated range lies above it.
By their numbers in this assay, from the lowest: compounds 1, 4 and 3 (each within the scatter of the next, the first and the last beyond it); then compound 2.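

In this assay, putting bromo in place of methoxy on the aromatic carbon para to a large group gives a 1.9-fold lower number from compound 3 to compound 4 (0.29 log units; within the scatter), so the two compounds cannot be told apart on this read-out. For the compounds shown here, this is the first pair in which the change stands alone, and it shows that with the rest of compound 3 held fixed, this swap gives no shift beyond the usual scatter, even though a group of two heavy atoms with a hydrogen-bond acceptor gives way to a single bromine atom with none. Nothing measured here bears on the reason for this result.

Methoxy and bromo are the only two groups shown at this position with the rest of the molecule held fixed, so a single pair cannot say how much room for change the position has, and an amine, a carboxylic acid or a longer chain such as butoxy could behave quite differently there. From the compounds shown here alone, it also remains open whether the swap would read the same way if the other aromatic ring carried something other than the two chlorines of compound 3 and compound 4.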